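From compound 2 to compound 4: a pyridine in the side chain

The compounds below may be only part of what the source reports. "The series", "measured", "known", "first", "only" and "open" are said of these compounds alone.

Of the compounds shown here, three sharing one core have been measured in a functional assay on BMMC cells (Mus musculus, strain C57BL/6) for inhibition, with stated times of 5 days and 48 h; a higher number here means a weaker inhibitor, a lower number a stronger inhibitor. Compound 1 `C=C1CC[C@@H]2[C@](C)(CNCc3ccccc3)[C@H](O)CC[C@@]2(C)[C@@H]1/C=C/C1=CCOC1=O` gives 960 nM. Compound 2 `C=C1CC[C@@H]2[C@](C)(CNCc3ccc(C)cc3)[C@H](O)CC[C@@]2(C)[C@@H]1/C=C/C1=CCOC1=O` gives 740 nM in this assay, and compound 3 `C=C1CC[C@@H]2[C@](C)(CNCc3ccc(Cl)cc3)[C@H](O)CC[C@@]2(C)[C@@H]1/C=C/C1=CCOC1=O` gives 420 nM. On these numbers compound 2 stands second highest of the three: the step of a 1.3-fold lower number from compound 1 to compound 2 (0.11 log units; within the scatter) lies within the scatter, as does a 1.8-fold lower number from compound 2 to compound 3 (0.25 log units; within the scatter), while a 2.3-fold lower number from compound 1 to compound 3 (0.36 log units; beyond the scatter) is a modest step beyond it.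

Compound 4 `C=C1CC[C@@H]2[C@](C)(CNCc3ccncc3)[C@H](O)CC[C@@]2(C)[C@@H]1/C=C/C1=CCOC1=O` has not yet been measured. It differs from compound 2 in one place: pyridin-4-yl in place of 4-methylphenyl on a saturated chain carbon bound to an amine nitrogen. Going by the values given here, none of the measured steps alters the aromatic ring itself; they change only a substituent on it, and they show that such changes move the number little, as in a 1.3-fold lower number from compound 1 to compound 2 (0.11 log units; within the scatter) and a 1.8-fold lower number from compound 2 to compound 3 (0.25 log units; within the scatter), and at most modestly, as in a 2.3-fold lower number from compound 1 to compound 3 (0.36 log units; beyond the scatter). The expectation for this assay is therefore a step of no more than the scatter, in either direction. Compound 4 is estimated at 1100 nM, within 500 nM to 2500 nM. The step of a 1.5-fold higher number from compound 2 to compound 4 (0.17 log units; within the scatter) is expected to be small.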

Compound 4, half-maximal inhibitory concentration: 2030 nM
The estimate for compound 4 lay 1.8-fold (0.27 log units) below the measured number; the range from low to high includes it.
By their numbers in this assay, from the lowest: compounds 3, 2 and 1 (each within the scatter of the next, the first and the last beyond it); then compound 4.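

On a saturated chain carbon bound to an amine nitrogen, putting pyridin-4-yl in place of a carbon-only aromatic ring raises the number in this assay in every comparison: a 2.1-fold higher number from compound 1 to compound 4 (0.33 log units; beyond the scatter), a 2.7-fold higher number from compound 2 to compound 4 (0.44 log units; beyond the scatter) and a 4.8-fold higher number from compound 3 to compound 4 (0.68 log units; beyond the scatter). The step from compound 1 is the cleanest reading, since there the change concerns the ring itself and no substituent is involved, yet it still lies beyond the scatter, as the substituent step from compound 1 to compound 2 did not. All three steps are modest, but compound 4 is now the weakest inhibitor of the four.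

Nothing at hand gives a reason for this rise. Going by these compounds, whether a thiophene or a saturated ring such as cyclohexyl at this place would stand with the phenyl compounds or with compound 4 remains open.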